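The compounds below may be only part of what the source reports. "The series", "measured", "known", "first", "only" and "open" are said of these compounds alone.

Measured compounds:
- Compound 1 `CC1=C(C(=O)OC(C)(C)C)C(c2cccs2)NC(=O)N1`: 26%
- Compound 2 `CCNC(=O)C1=C(C)NC(=O)NC1c1cccs1`: 1%
- Compound 3 `CCN(CC)C(=O)C1=C(C)NC(=O)NC1c1cccs1`: 13%

In an assay on membranes from CHO cells for displacement of a labelled ligand from adenosine receptor A1 (Homo sapiens), read by scintillation counting, with a stated time of 60 min, tested at 1 uM (on this read-out lower numbers stand for less inhibition and higher numbers for more inhibition at the one concentration tested (going by the name of the read-out)), compound 3 gives 13% and stands second among the three numbers. Its nearest neighbour is compound 2, with a result a number 12 percentage points higher from compound 2 to compound 3 (beyond the scatter) when ethyl replaces hydrogen on an amide-type nitrogen. Its furthest neighbour is compound 1, which lies on the other side: compound 1 gives 26% and the change from its tert-butoxy ester to a diethylamino amide brought a number 13 percentage points lower from compound 1 to compound 3 (beyond the scatter). The related swap from tert-butoxy to ethylamino gave a number 25 percentage points lower from compound 1 to compound 2 (beyond the scatter).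

Compound 4 `CC1=C(C(=O)OC2CCC2)C(c2cccs2)NC(=O)N1` has not yet been tested in this assay. It differs from compound 3 in one place: cyclobutyloxy in place of diethylamino on a carbonyl carbon. This returns the carbonyl carbon from an amide to an ester, now with a four-membered ring on the oxygen. Going by the values given here, the step that bears on it most is the one from compound 1 to compound 3, where losing the ester cost a number 13 percentage points lower from compound 1 to compound 3 (beyond the scatter); undoing that in compound 4 is expected to recover a step of about the same size in the opposite direction, a number 11 percentage points higher from compound 3 to compound 4 (beyond the scatter). Among the compounds with values here, no measured step shows how a cyclobutyloxy compares with a tert-butoxy ester, so the range is kept wide. Compound 4 is therefore expected to give 24%, within 10% to 40%.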

Compound 4, a percentage reported as inhibition, at one concentration (the size of the read-out at that concentration, not a potency): 24%
Estimate against measurement, compound 4: no gap at the digits printed; the measured number falls inside the stated range.
By their numbers in this assay, from the lowest: compound 2; then compound 3; then compounds 4 and 1 (each within the scatter of the next).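

In this assay, the change from tert-butyl to cyclobutyl on the oxygen of the ester gives a number 2 percentage points lower from compound 1 to compound 4 (within the scatter) and so leaves the two esters indistinguishable, which shows that this position accepts a four-membered ring of carbon only as well as it accepts the open, branched tert-butyl group. The amides now fall short of a second ester, not just of one: replacing diethylamino with cyclobutyloxy gives a number 11 percentage points higher from compound 3 to compound 4 (beyond the scatter) and replacing ethylamino with cyclobutyloxy gives a number 23 percentage points higher from compound 2 to compound 4 (beyond the scatter), so among these four compounds both esters stand above both amides, and none goes against that pattern. Nothing measured here explains this difference between esters and amides.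

Going by these compounds, whether the pattern extends to a methyl ester, a longer chain such as n-hexyloxy, a larger ring such as cyclohexyloxy or a carboxylic acid on this carbonyl carbon remains open. Each number also comes from a single concentration, so the compounds shown give the size of the read-out at that concentration and leave their potencies unknown.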